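A few compounds are considered here, and "the series" means these few. Any claim that something is new, unique, unknown or untested is made for them only; others in the source may bear on it.

Measured so far in a functional assay on NALM-6 cells (Homo sapiens) for cytotoxicity, with a stated time of 72 h (on this read-out lower numbers stand for an effect already at smaller amounts and higher numbers for an effect only at larger amounts of compound), all three values being limits:
- compound 1 `C=C[C@@](C)(/C=C/c1ccc(OS(=O)(=O)c2ccc(C)cc2)cc1)CCC=C(C)C`: > 43400 nM
- compound 2 `C=C[C@@](C)(/C=C/c1ccc(O)cc1)CCCO`: > 43400 nM
- compound 3 `C=C[C@@](C)(/C=C/c1ccc(O)c(/C=C/C#N)c1)CCC=C(C)C`: > 43400 nM

The series gives no number yet, only (the limit of > 43400 nM in this assay, at which 3 of the 3 values shown sit). Compound 3 stands at > 43400 nM, which is a limit of the assay.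

Compound 4 `C=C[C@@](C)(/C=C/c1ccc(O)c(/C=C/c2ccc(F)cc2)c1)CCC=C(C)C` differs from compound 3 in one place: 4-fluorophenyl in place of cyano on a double-bonded chain carbon bound to a double-bonded chain carbon. In words, 4-fluorophenyl takes the place of cyano on a double-bonded chain carbon bound to a double-bonded chain carbon, so that 2-cyanoethenyl becomes 2-(4-fluorophenyl)ethenyl.

Within the data shown here, no step between measured compounds is available to size this change in this assay. A modest move towards lower numbers is expected, though compound 4 may equally stay at the limit. The expected step, an at least 1.9-fold lower number from compound 3 to compound 4 (0.29 log units; that floor lies within the scatter), is a rough estimate, since it starts from a limit and not from a number. Compound 4 is estimated at 22000 nM, with an expected range of 7000 nM to 43400 nM.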

Compound 4, half-maximal effective concentration: > 43400 nM
Compound 4: only a limit was reported; the forecaster's own chance of this, stated with the estimate: 50%; at least 1.9-fold (0.29 log units) between middle value and limit.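

In this assay compound 3 and compound 4 both give only limits, and no step can be read between them. The compounds shown leave open whether any change to the shared core brings a measurable value, as all results so far sit at one limit: the limit of > 43400 nM in this assay, at which 4 of the 4 values shown sit.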